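Fluoro entering the aniline ring of compound 2

A few compounds are considered here, and "the series" means these few. Any claim that something is new, unique, unknown or untested is made for them only; others in the source may bear on it.

Compound 2 `CCOC(=O)c1ccc(Nc2ccnc(-c3cccnc3)n2)cc1` gives 61000 nM in a physicochemical assay for solubility, in phosphate buffer; a higher number here means a more soluble compound, a lower number a less soluble compound. Compound 1 `CCOC(=O)c1ccc(Nc2ccnc(-c3ccncc3)n2)cc1` gives 52000 nM in this assay, and the step of a 1.2-fold higher number from compound 1 to compound 2 (0.07 log units; within the scatter) shows the two numbers do not differ beyond the scatter. Compound 3 `CCOC(=O)c1ccc(Nc2ccnc(-c3cccnc3)n2)c(F)c1` differs from compound 2 by fluoro in place of hydrogen on an aromatic carbon. For the measured compounds named here, no measured step concerns a fluoro for hydrogen exchange; the only step, a 1.2-fold higher number from compound 1 to compound 2 (0.07 log units; within the scatter), touches another part of the molecule and was within the scatter. The step of a 1.2-fold lower number from compound 2 to compound 3 (0.09 log units; within the scatter) is therefore expected to stay within the scatter. Compound 3 is estimated at 50000 nM, with a range from 25000 nM to 100000 nM.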

Compound 3, solubility: 53000 nM
For compound 3 the middle estimate is 1.1-fold (0.03 log units) below the measured one; low and high end bracket the measured number.
By their numbers in this assay, from the lowest: compounds 1, 3 and 2 (each within the scatter of the next).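

In this assay, fluoro in place of hydrogen on an aromatic carbon, ortho to a large group and meta to an ethoxycarbonyl group, gives a step that stays within the scatter (a 1.2-fold lower number from compound 2 to compound 3 (0.06 log units; within the scatter)). This position therefore tolerates fluoro without a shift that can be told apart from the scatter, and the earlier step touched another part of the molecule. No supporting measurement bears on this result.

As far as these compounds go, whether an amine, a carboxylic acid or a longer chain at this position would also stay within the scatter remains open. Also open, from the compounds shown here alone, is whether fluoro gives the same outcome alongside the pyridin-4-yl of compound 1.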